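The source may report more compounds than this note shows. Statements on the series, on what has been measured and on what is new or still open speak of the compounds shown alone.

Series notes on the shared core of compound 1, a nitro-substituted benzamide carrying a methylsulfonyl group, tested in an assay on isolated protein for inhibition of vitamin D3 receptor (Homo sapiens), read by fluorescence polarization; on this read-out higher numbers stand for weaker inhibition and lower numbers for stronger inhibition.

Compound 1 `CS(=O)(=O)c1ccc(C(=O)N2CCC(C(=O)N(Cc3ccccc3)Cc3ccccc3)CC2)cc1[N+](=O)[O-]` returns only a limit in this assay, > 60000 nM. Compound 2 `CS(=O)(=O)c1ccc(C(=O)NCCCC(=O)N2CCCCC2)cc1[N+](=O)[O-]` likewise gives a limit in this assay, > 60000 nM. Compound 3 `CN(Cc1ccccc1F)C(=O)CNC(=O)c1ccc(S(C)(=O)=O)c([N+](=O)[O-])c1` also reports a limit in this assay, > 60000 nM. Among the compounds with values here, with every value sitting at the limit of > 60000 nM in this assay, at which 3 of the 3 values shown sit, compound 1 cannot be placed above or below compound 2 or compound 3; no ordering within the measured set is possible, and no step between measured compounds can be quantified.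

Compound 4 `CS(=O)(=O)c1ccc(C(=O)N2CCC(C(=O)N(Cc3ccccc3)c3ccccc3)CC2)cc1[N+](=O)[O-]` is the untested member. It differs from compound 1 by phenyl in place of benzyl on an amide-type nitrogen. The retained amide-type nitrogen keeps one benzyl substituent and the piperidine carboxamide link to the core is unchanged.

Since compound 1 gives > 60000 nM in this assay and the other two measured analogues show the same limit, the expected step that the limit leaves unreadable from compound 1 to compound 4 is small and of no settled direction, with the reading most likely to remain a limit rather than a number. For compound 4 in this assay the estimate is 90000 nM, with a range from 20000 nM to 400000 nM.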

Compound 4, half-maximal inhibitory concentration: > 60000 nM
Compound 4 was reported as a limit (the forecaster's own chance of this, stated with the estimate: 85%); the middle value is on the limit's open side.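

Compound 4, like compound 1, reads as a limit in this assay, so the step for phenyl in place of benzyl cannot be read: the limit of > 60000 nM in this assay, at which 4 of the 4 values shown sit.

The compounds shown leave open which changes to the shared core, if any, would give a number rather than a limit in this assay.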